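A few compounds are considered here, and "the series" means these few. Any claim that something is new, unique, unknown or untested is made for them only; others in the source may bear on it.

Measured in a physicochemical assay for lipophilicity; on this read-out higher numbers stand for higher lipophilicity and lower numbers for lower lipophilicity:
compound 1 `CCOC(=O)C1=C(C)NC(=S)NC1c1cn(C(=O)CNc2ccc([N+](=O)[O-])c(Cl)c2)c2ccccc12`: 3.4
compound 2 `CCOC(=O)C1=C(C)NC(=O)NC1c1cn(C(=O)CNc2ccc([N+](=O)[O-])cc2Cl)c2ccccc12`: 1.99
compound 3 `CCOC(=O)C1=C(C)NC(=S)NC1c1cn(C(=O)CNc2cccc([N+](=O)[O-])c2)c2ccccc12`: 2.88

Compound 2 stands lowest of the three numbers; compound 3 lies above it and compound 1 above both, each gap beyond the scatter. Compound 4 `CCOC(=O)C1=C(C)NC(=O)NC1c1cn(C(=O)CNc2cccc([N+](=O)[O-])c2)c2ccccc12` differs from compound 2 in one place: 3-nitrophenyl in place of 2-chloro-4-nitrophenyl on an amine nitrogen. Among the compounds with values here, the only measured step that bears on this change is a number 0.52 log units lower from compound 1 to compound 3 (beyond the scatter), where the group that leaves is 3-chloro-4-nitrophenyl rather than 2-chloro-4-nitrophenyl, while the group that enters is the same 3-nitrophenyl. A downward step of similar size in this assay is therefore expected, a number 0.49 log units lower from compound 2 to compound 4 (beyond the scatter). Compound 4 is estimated at 1.5, with a range from 1 to 2.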

Compound 4, partition coefficient: 1.48
The estimate for compound 4 lay 0.02 log units above the measured number; the measured number falls inside the stated range.
By their numbers in this assay, from the lowest: compound 4; then compound 2; then compound 3; then compound 1.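

In this assay the new result is a number 0.51 log units lower from compound 2 to compound 4 (beyond the scatter), which gives the change to 3-nitrophenyl a measured step with 2-chloro-4-nitrophenyl as the group that leaves, on the core of compound 2. It runs in the same direction and is of much the same size as a number 0.52 log units lower from compound 1 to compound 3 (beyond the scatter), where 3-chloro-4-nitrophenyl leaves. No evidence on the cause of either step is at hand.

The compounds shown leave open where a methoxy group or an amine on this phenyl ring would place the number. They also leave open how the two chloro-nitrophenyl groups compare on one core.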